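The source may report more compounds than this note shows. Statements on the series, on what has been measured and on what is new or still open speak of the compounds shown alone.

Measured compounds:
compound 1 `Cc1ccc(S(=O)(=O)NC(=O)Nc2ccccc2C(=O)/C=C/c2cccc([N+](=O)[O-])c2)cc1` — 44.5 ug/mL
compound 2 `Cc1ccc(S(=O)(=O)NC(=O)Nc2ccccc2C(=O)/C=C/c2cc(O)ccc2[N+](=O)[O-])cc1` — 18.3 ug/mL

In an ADME assay on the whole organism for cytotoxicity, with Artemia salina as the target, with a stated time of 24 h (a higher number here means that more compound is needed for the effect, a lower number that less compound is needed), compound 2 gives the lowest of the two numbers, 18.3 ug/mL, while compound 1 gives 44.5 ug/mL. Compound 3 `Cc1ccc(S(=O)(=O)NC(=O)Nc2ccccc2C(=O)/C=C/c2ccc[nH]2)cc1` differs from compound 2 by 1H-pyrrol-2-yl in place of 5-hydroxy-2-nitrophenyl on a double-bonded chain carbon bound to a double-bonded chain carbon. Going by the values given here, the one measured step, a 2.4-fold lower number from compound 1 to compound 2 (0.39 log units; beyond the scatter), also swapped the group at this place and was modest, but it says nothing about the 1H-pyrrol-2-yl group, so the direction here is uncertain. A modest step is expected, a 1.9-fold higher number from compound 2 to compound 3 (0.28 log units; within the scatter), with a wide range. Compound 3 is therefore estimated at 35 ug/mL, between 12 ug/mL and 100 ug/mL.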

Compound 3, concentration for half-maximal effect: 32.1 ug/mL
For compound 3 the middle estimate is 1.1-fold (0.04 log units) above the measured one; the range from low to high includes it.
By their numbers in this assay, from the lowest: compounds 2, 3 and 1 (each within the scatter of the next, the first and the last beyond it).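

In this assay, 1H-pyrrol-2-yl in place of 5-hydroxy-2-nitrophenyl gives a 1.8-fold higher number from compound 2 to compound 3 (0.24 log units; within the scatter), and in place of 3-nitrophenyl it gives a 1.4-fold lower number from compound 1 to compound 3 (0.14 log units; within the scatter). So at this place on the chain, a five-membered aromatic ring with no nitro group gives a number that cannot be told apart from those of either nitro-bearing compound. Nothing measured here explains this result.

Still open, as far as these compounds go, is whether an unsubstituted phenyl ring would give a similar number. From the compounds shown here alone, it is also open whether a group without any ring, such as a carboxylic acid or an amine, would move the number beyond the scatter.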